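The source may report more compounds than this note shows. Statements on the series, on what has been measured and on what is new or still open speak of the compounds shown alone.

Measured so far:
compound 1 `CC(C(=O)O)c1ccc(NCc2cccc(Oc3ccccc3)c2)cc1`, 16600 nM
compound 2 `O=C(O)CCc1ccc(NCc2ccc(C(F)(F)F)cc2)cc1`, 2000 nM
compound 3 `O=C(O)CCc1ccc(NCc2cccnc2)cc1`, < 31700 nM

In a functional assay for agonist activity at Free fatty acid receptor 1 (Homo sapiens) (a higher number here means that more compound is needed for the effect, a lower number that less compound is needed), compound 2 gives 2000 nM, the lowest of the two numbers obtained. Compound 1 gives 16600 nM in this assay, a gap beyond the scatter. Compound 3 sits at the limit of < 31700 nM in this assay, at which 1 of the 3 values shown sits; its value < 31700 nM is a limit of the assay, not a number. Compound 4 `O=C(O)CCc1ccc(NCc2ccc(C(=O)O)cc2)cc1` is not yet measured. It differs from compound 2 by carboxy in place of trifluoromethyl on an aromatic carbon, para to a large group. Among the measured compounds shown here, no measured step covers this change; a step toward higher numbers, beyond the scatter, is expected, a 7.5-fold higher number from compound 2 to compound 4 (0.88 log units; beyond the scatter). Compound 4 is accordingly estimated at 15000 nM, with a range from 4000 nM to 50000 nM, and a fair chance that only a limit is reported.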

Compound 4, half-maximal effective concentration: < 31700 nM
Compound 4: only a limit was reported; the forecaster's own chance of this, stated with the estimate: 40%; the middle value is on the limit's open side.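

Among the compounds shown here, compound 4 stands at < 31700 nM in this assay, a limit and not a number, so no step from compound 2 to compound 4 can be read. The compounds shown leave open how far carboxy in place of trifluoromethyl shifts the value.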